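The source may report more compounds than this note shows. Statements on the series, on what has been measured and on what is new or still open speak of the compounds shown alone.

The series is built on a shared core carrying a triazole bearing an amide, with a 1-aminoisoquinolin-6-yl group attached through a saturated chain carbon bound to an amide-type nitrogen. Compound 1 `Nc1nccc2cc(CNC(=O)Cn3cnc(C(=O)NC4CCCCC4)n3)ccc12` belongs to this set, but in an assay on isolated protein for inhibition of histone-lysine N-methyltransferase SETD7 (Homo sapiens), read by 33P incorporation (a lower number here means a stronger inhibitor, a higher number a weaker inhibitor), compound 1 gives "not determined" (no result reported). Compound 3 `Cc1ccc(NC(=O)c2ncn(CC(=O)NCc3ccc4c(N)nccc4c3)n2)cc1C` also belongs to it, and in this assay compound 3 likewise gives "not determined" (no result reported). Among the measured compounds shown here, compound 2 `CC(C)(C)c1ccc(NC(=O)c2ncn(CC(=O)NCc3ccc4c(N)nccc4c3)n2)cc1` therefore stands alone with a number: in this assay compound 2 gives 79800 nM, which is very weak, and it is the only value available, so no step between measured compounds can be drawn.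

Compound 4 `CC(C)(C)c1ccc(NC(=O)c2ncn(CC(=O)NCc3ccc4[nH]ncc4c3)n2)cc1` differs from compound 2 in one place: 1H-indazol-5-yl in place of 1-aminoisoquinolin-6-yl on a saturated chain carbon bound to an amide-type nitrogen. For the measured compounds named here, with no measured step to compare against, the expectation rests only on compound 2 itself, whose 79800 nM leaves little room to weaken further. The step from compound 2 to compound 4 is estimated as a 1.5-fold higher number from compound 2 to compound 4 (0.18 log units; within the scatter), which is expected to stay within the scatter or drift slightly toward weaker inhibition. Compound 4 is accordingly expected to give about 120000 nM in this assay, within a range from 40000 nM to 400000 nM.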

Compound 4, half-maximal inhibitory concentration: "not active" (no number reported)
The entry for compound 4 holds no number, so the estimate cannot be set against anything.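

In this assay compound 4 gives "not active" (no number reported) and so no step can be read from compound 2 to compound 4. Nothing shown here accounts for this result. The compounds shown leave open how 1H-indazol-5-yl and 1-aminoisoquinolin-6-yl compare numerically on the shared core.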